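A few compounds are considered here, and "the series" means these few. Any claim that something is new, unique, unknown or untested is made for them only; others in the source may bear on it.

Measured compounds:
compound 1 `COc1cc(C)cc(-c2c(-c3ccnc(-c4ccc(C(C)=O)cc4)c3)cnn2CC#N)c1` — 81%
compound 2 `COc1cc(C)cc(-c2nn(CC#N)cc2-c2ccnc(-c3ccc(N(C)C)cc3)c2)c1` — 28%

In a functional assay on UACC-257 cells (Homo sapiens) for cytotoxicity, read by sulforhodamine B assay, with a stated time of 48 h, tested at 100 nM (a higher number here means a weaker effect of the compound at the concentration tested, a lower number a stronger effect), compound 1 gives 81%, the highest of the two numbers and therefore the weaker effect of the pair at the concentration tested. In the same assay compound 2 gives 28%, a number that lies well beyond the scatter below that of compound 1. For the measured compounds named here, no step between these two compounds is given, as they differ in more than one place; their values show only that compound 2 reaches the stronger effect.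

Compound 3 `COc1cc(C)cc(-c2c(-c3ccnc(-c4ccc(N(C)C)cc4)c3)cnn2CC#N)c1` has not yet been measured in this assay. It differs from compound 1 in one place: dimethylamino in place of acetyl on an aromatic carbon. The same group that enters here is also present in compound 2, which gives the lower number.

On this basis the step of a number 39 percentage points lower from compound 1 to compound 3 (beyond the scatter) is expected to go downward and beyond the scatter, toward a stronger effect. The value for compound 3 is estimated at 42%, within a range from 20% to 72%.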

Compound 3, a percentage reported as activity, at one concentration (the size of the read-out at that concentration, not a potency): 41%
Beside the measured number, compound 3's estimate is 1 percentage points above it; measured number inside the range.
By their numbers in this assay, from the lowest: compound 2; then compound 3; then compound 1.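

Within this assay, the exchange of 4-acetylphenyl for 4-(dimethylamino)phenyl is now seen on its own, with the rest of the molecule held fixed: a number 40 percentage points lower from compound 1 to compound 3 (beyond the scatter). The earlier pair differed in more than one place and could not tie any part of its gap to this group, whereas this step shows that the change at this position alone moves the number toward a stronger effect. The two groups match in heavy-atom count and hydrogen-bond acceptor count, and neither brings a ring or a net charge, so those counts do not separate them, and no measurement of any property of either group accompanies the result.

What the compounds shown leave open is whether a primary amine, a methoxy group or a carboxylic acid on this aromatic carbon would give a number closer to that of compound 3 or to that of compound 1. They also leave open whether the same exchange has a step of similar size on the core of compound 2, and whether the stronger and weaker effects seen at the concentration tested would hold at any other concentration; each number comes from a single concentration.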